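A few compounds are considered here, and "the series" means these few. Any claim that something is new, unique, unknown or untested is made for them only; others in the source may bear on it.

In a functional assay on A-375 cells (Homo sapiens) for antiproliferative activity (on this read-out lower numbers stand for stronger inhibition and higher numbers for weaker inhibition), compound 1 `O=C(Nc1ccc(-c2cscn2)cc1)C1CCCN(Cc2ccc(F)c(F)c2)C1` gives 880 nM and compound 2 `O=C(Nc1ccc(-c2ccncc2)cc1)C1CCCN(Cc2ccc(F)c(F)c2)C1` gives 600 nM. These two numbers lie within the scatter of each other, so the pair offers no real ranking, and compound 2 stands level with compound 1 on the evidence so far.

The next structure, compound 3 `O=C(Nc1ccc(-c2c[nH]cn2)cc1)C1CCCN(Cc2ccc(F)c(F)c2)C1`, keeps the shared core and changes only the aromatic ring carried on it: 1H-imidazol-4-yl in place of pyridin-4-yl on an aromatic carbon. In words, this places 1H-imidazol-4-yl in place of pyridin-4-yl on an aromatic carbon.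

Within the data shown here, only one measured step bears on this change, since it alters the same place: a 1.5-fold lower number from compound 1 to compound 2 (0.17 log units; within the scatter). It exchanges one aromatic ring for another and remains within the scatter. Among the measured compounds shown here, that single step suggests that this assay may tolerate such exchanges, though no measured compound shows what the imidazole hydrogen-bond donor does here, so the range must stay wide.

The estimated step is a 1.3-fold higher number from compound 2 to compound 3 (0.12 log units; within the scatter), which is expected to stay within the scatter. Compound 3 is expected at about 800 nM, within an estimated range of 300 nM to 2500 nM.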

Compound 3, half-maximal inhibitory concentration: > 20000 nM
Compound 3 was reported as a limit (the forecaster's own chance of this, stated with the estimate: 5%); middle value at least 25-fold (1.39 log units) away from the limit.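

Compared with the earlier exchange of aromatic rings at this place, on an aromatic carbon para to a large group, 1H-imidazol-4-yl changes the picture in this assay with an at least 33-fold higher number from compound 2 to compound 3 (1.52 log units; beyond the scatter) and with an at least 22-fold higher number from compound 1 to compound 3 (1.35 log units; beyond the scatter). The earlier step within the scatter therefore does not mean that every aromatic ring is accepted here, and both pyridin-4-yl and 1,3-thiazol-4-yl go against any such reading of compound 3. The entry for compound 3 is a limit of the assay and not a number: the limit of > 20000 nM in this assay, at which 1 of the 3 values shown sits.

The compounds shown do not separate the hydrogen-bond donor of 1H-imidazol-4-yl from the rest of that ring, so it stays open whether 1-methylimidazol-4-yl, with a methyl group on the ring nitrogen that carries the hydrogen, would return to the level of the first two compounds. From the compounds shown here alone, it also stays open how an isomeric ring such as pyrazol-4-yl, or a phenyl ring carrying a hydroxyl or an amine, would read at this same place.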